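A Double Bond Flipped on an Inactive Scaffold

This account rests on a few compounds, and the source may have more. Where it says the series, first, only, none or still open, it means among the compounds named here.

Of the compounds shown here, three built on a shared core have been tested in a functional assay on BT-549 cells (Homo sapiens) for inhibition, read by MTT assay, with a stated time of 48 h; a lower number here means a stronger inhibitor, a higher number a weaker inhibitor. Compound 1 (`CC(=O)c1ccc2c(c1)/C(=C/c1cccc(OCc3cn(Cc4ccccc4)nn3)c1)C(=O)N2`) returned only a limit of the assay, > 50000 nM, and not a number. Compound 2 (`COc1ccc(Cc2ccc3c(c2)/C(=C\c2cccc(OCc4cn(Cc5ccccc5)nn4)c2)C(=O)N3)cc1`) likewise gave a limit, > 50000 nM. Compound 3 (`Cc1ccc(C(C#Cc2ccccc2)c2ccc3c(c2)/C(=C/c2cccc(OCc4cn(Cc5ccccc5)nn4)c2)C(=O)N3)cc1`) also sits at a limit, > 50000 nM. Compound 3 thus stands exactly where every measured compound stands, at the limit of > 50000 nM in this assay, at which 3 of the 3 values shown sit; no number separates any of them.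

Compound 4 (`Cc1ccc(C(C#Cc2ccccc2)c2ccc3c(c2)/C(=C\c2cccc(OCc4cn(Cc5ccccc5)nn4)c2)C(=O)N3)cc1`) has the same atoms and bonds as compound 3; the two differ only in the two compounds have the same atoms and bonds; at least one stereo element is drawn with a configuration in one of them and without one in the other: 1 of 2 stereo elements differ; a double bond is drawn Z in compound 3 and E in compound 4. For the measured compounds named here, no step between measured compounds is available, so the effect of this change cannot be read from the data. Going by the values given here, with every value so far a limit, the expected step from compound 3 to compound 4 in this assay is a step that the limit leaves unreadable from compound 3 to compound 4, meaning none beyond the scatter in either direction. Compound 4 is therefore expected to give about 60000 nM in this assay, within 10000 nM to 200000 nM, most probably reported again as a limit.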

Compound 4, half-maximal inhibitory concentration: > 50000 nM
Compound 4: a limit, no number; the forecaster's own chance of this, stated with the estimate: 85%; the middle value does not contradict the limit.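

For the compounds shown here, compound 3 and compound 4 both end at a limit of the assay and not at a number, so no step between them can be read: the limit of > 50000 nM in this assay, at which 4 of the 4 values shown sit. The compounds shown leave open whether either double bond geometry on this shared core gives any measurable inhibition in this assay.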